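A few compounds are considered here, and "the series" means these few. Any claim that something is new, unique, unknown or untested is made for them only; others in the source may bear on it.

Measured compounds in a functional assay on HCT-116 cells (Homo sapiens), read by MTT assay, with a stated time of 72 h; a higher number here means a weaker inhibitor, a lower number a stronger inhibitor:

- Compound 1, `O=c1[nH]cnc2c1c(-c1cccs1)cn2[C@@H]1O[C@H](CO)[C@@H](O)[C@H]1O`, gives > 20000 nM, which is a limit of the assay rather than a number.
- Compound 2, `O=c1[nH]cnc2c1c(-c1ccsc1)cn2[C@@H]1O[C@H](CO)[C@@H](O)[C@H]1O`, gives > 20000 nM, again a limit of the assay.
- Compound 3, `O=c1[nH]cnc2c1c(-c1cc3ccccc3o1)cn2[C@@H]1O[C@H](CO)[C@@H](O)[C@H]1O`, gives > 20000 nM, also a limit of the assay.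

Compound 3 therefore stands where every value shown stands: at the limit, with no number behind it. All three of the values sit there, (the limit of > 20000 nM in this assay, at which 3 of the 3 values shown sit), so none of the steps among these compounds can be sized. The step that the two limits leave unreadable from compound 1 to compound 2 is unreadable, as are a step that the two limits leave unreadable from compound 1 to compound 3 and a step that the two limits leave unreadable from compound 2 to compound 3.

The next compound, compound 4, is `O=c1[nH]cnc2c1c(-c1ccccc1)cn2[C@@H]1O[C@H](CO)[C@@H](O)[C@H]1O`. It differs from compound 3 in one place: phenyl in place of 1-benzofuran-2-yl on an aromatic carbon. The two measured steps that touch the 1-benzofuran-2-yl group, from compound 1 and from compound 2 to compound 3, give no readable size, so they offer no direction for this change. In this assay, the expected step that the limit leaves unreadable from compound 3 to compound 4 is therefore none that can be read, and compound 4 is expected most likely to sit at the same limit. The estimate for compound 4 is 30000 nM, with a range from 5000 nM to 150000 nM.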

Compound 4, half-maximal inhibitory concentration: > 100000 nM
Compound 4 ended at the assay's limit; the forecaster's own chance of this, stated with the estimate: 85%; at least 3.3-fold (0.52 log units) between middle value and limit.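

Compound 4 gives > 100000 nM, which is a limit of the assay and not a number, so its steps from compound 1, compound 2 and compound 3 cannot be read. The compounds shown leave open how phenyl, thiophen-2-yl, thiophen-3-yl and 1-benzofuran-2-yl rank against one another.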